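This account rests on a few compounds, and the source may have more. Where it says the series, first, only, none or still open, it means among the compounds named here.

Notes on the series, following the step from compound 2 to compound 3 in a physicochemical assay for solubility, read by HPLC, using the shake flask method, measured as kinetic solubility, with a stated time of 2 h, at pH 7.4; a higher number here means a more soluble compound, a lower number a less soluble compound. Of the compounds shown here, two of the shared core have been measured. Compound 1 `Cc1cc(NCc2ccccn2)n2ncc(Br)c2n1` gives 89300 nM in this assay. Compound 2 `Cc1cc(NCc2ccccn2)n2ncc(-c3ccncc3)c2n1` gives 161000 nM in this assay. Among the measured compounds shown here, the only measured step, a 1.8-fold higher number from compound 1 to compound 2 (0.26 log units; within the scatter), does not separate the two, so on the numbers so far compound 2 stands together with compound 1 rather than apart from it. Compound 3 `Cc1cc(NCc2ccccn2)n2ncc(C3=CCC(F)(F)CC3)c2n1` is not yet measured; the change is 4,4-difluorocyclohex-1-en-1-yl in place of pyridin-4-yl on an aromatic carbon. For the measured compounds named here, no measured step bears directly on this change: the single step known exchanges bromo for pyridin-4-yl on the same aromatic carbon and stayed within the scatter, and nothing measured shows a non-aromatic ring entering there. The expectation is therefore loosely held and set as a modest decrease, a 3.6-fold lower number from compound 2 to compound 3 (0.55 log units; beyond the scatter). Compound 3 is estimated at 45000 nM in this assay, with a range of 12000 nM to 170000 nM.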

Compound 3, solubility: 5000 nM
For compound 3 the middle estimate is 9.0-fold (0.95 log units) above the measured one, and the stated range ends above it.
By their numbers in this assay, from the lowest: compound 3; then compounds 1 and 2 (each within the scatter of the next).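

In this assay, this aromatic carbon proves sensitive to the group it carries: 4,4-difluorocyclohex-1-en-1-yl gives a 32-fold lower number from compound 2 to compound 3 (1.51 log units; beyond the scatter) and an 18-fold lower number from compound 1 to compound 3 (1.25 log units; beyond the scatter). Bromo and pyridin-4-yl had stayed within the scatter of each other, so the first step beyond the scatter at this position is the one that brings in a non-aromatic ring of carbon only, with fluorine and no hydrogen-bond acceptor. Nothing measured here accounts for the drop.

As far as these compounds go, the entering group differs from pyridin-4-yl in several ways at once, so which of them matters remains open. A phenyl group or an unfluorinated cyclohexenyl group on the same carbon would separate the loss of the ring nitrogen and of aromaticity from the entry of fluorine.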